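The compounds below may be only part of what the source reports. "The series", "measured", "known", "first", "only" and "open" are said of these compounds alone.

Compound 1, with the structure `CC(=O)Nc1ccc(S(=O)(=O)Oc2ccccc2C(C)C)cc1`, is one of two measured members of this small series. In a functional assay on HT-29 cells (Homo sapiens) for antiproliferative activity, read by sulforhodamine B assay, with a stated time of 48 h (on this read-out higher numbers stand for weaker inhibition and lower numbers for stronger inhibition), compound 1 gives 23000 nM. Its companion, compound 2, with the structure `CC(=O)Nc1ccc(S(=O)(=O)Oc2ccccc2I)cc1`, gives in this assay a value of 23000 nM. Going by the values given here, the single measured step, no change at the digits printed from compound 1 to compound 2 (within the scatter), involved an iodo in place of an isopropyl on an aromatic carbon. Compound 1 therefore stands level with compound 2, and neither can be called the stronger of the two.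

Compound 3, with the structure `CCC(=O)Nc1ccc(S(=O)(=O)Oc2ccccc2C(C)C)cc1`, has not yet been measured. It differs from compound 1 by methyl in place of hydrogen on a saturated chain carbon bound to a carbonyl carbon, turning acetamido into propanoylamino. Among the compounds with values here, the only measured step touches the aromatic substituent, not the amide chain, so it bears on this change only by showing that the series tolerated one variation without movement. For compound 3 the estimated step is no change at the digits printed from compound 1 to compound 3 (within the scatter), with no change expected beyond the scatter. Compound 3 is thus expected to give 23000 nM, within a range from 8000 nM to 60000 nM.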

Compound 3, half-maximal inhibitory concentration: 7400 nM
For compound 3 the middle estimate is 3.1-fold (0.49 log units) above the measured one, and the stated range ends above it.
By their numbers in this assay, from the lowest: compound 3; then compounds 1 and 2 (each within the scatter of the next).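

In this assay, the amide chain proves to be a place where a small change registers: methyl in place of hydrogen on a saturated chain carbon bound to a carbonyl carbon, turning acetamido into propanoylamino, gives a 3.1-fold lower number from compound 1 to compound 3 (0.49 log units; beyond the scatter) and so a modest step that lies beyond the scatter. The earlier pair had shown only that iodo in place of isopropyl on an aromatic carbon left the read-out unmoved, so this is the first sign that the series can respond to a structural change at all, and here a single added methyl is enough. No measurement available here accounts for the step, and its cause remains unassigned.

The compounds shown leave open whether the lower number continues with a longer chain such as butanoyl or a branched one such as isobutyryl, or whether it reverses once an amine or a carboxylic acid is carried on that chain. They also leave open whether propanoylamino in place of acetamido would give a step of similar size with iodo rather than isopropyl on the aromatic carbon.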